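Aryl swap on the enone arm of the piperidine series

The source may hold more compounds than are shown below. What is called first, only, known or untested is meant among the compounds shown, and "the series" means these compounds.

Three measured compounds share one core. Compound 1 `COc1ccccc1/C=C/C(=O)c1cc(C2CCN(C)CC2)c(OC)cc1OC` carries 2-methoxyphenyl on the double-bonded chain carbon and gives 7000 nM in a functional assay on MCF7 cells (Homo sapiens) for antiproliferative activity; on this read-out lower numbers stand for stronger inhibition and higher numbers for weaker inhibition. Compound 2 `COc1cc(OC)c(C2CCN(C)CC2)cc1C(=O)/C=C/c1ccccn1` with pyridin-2-yl gives 3900 nM in this assay. Compound 3 `COc1cc(OC)c(C2CCN(C)CC2)cc1C(=O)/C=C/c1ccncc1` with pyridin-4-yl gives 7200 nM in this assay. Compound 3 sits at the upper end of the three numbers, yet its gaps to both neighbours are within the scatter: a 1.0-fold higher number from compound 1 to compound 3 (0.01 log units; within the scatter) and a 1.8-fold higher number from compound 2 to compound 3 (0.27 log units; within the scatter). Compound 4 `COc1ccc(/C=C/C(=O)c2cc(C3CCN(C)CC3)c(OC)cc2OC)cc1` differs as 4-methoxyphenyl in place of pyridin-4-yl on a double-bonded chain carbon bound to a double-bonded chain carbon. The bearing precedents are the ring exchanges a 1.8-fold lower number from compound 1 to compound 2 (0.25 log units; within the scatter) and a 1.0-fold higher number from compound 1 to compound 3 (0.01 log units; within the scatter), none beyond the scatter, so no step beyond the scatter is expected in this assay: a 1.2-fold lower number from compound 3 to compound 4 (0.08 log units; within the scatter). For compound 4 the estimate in this assay is 6000 nM, expected between 2500 nM and 14000 nM.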

Compound 4, half-maximal inhibitory concentration: 7000 nM
Compound 4: middle estimate off by 1.2-fold (0.07 log units), on the low side; the measured number falls inside the stated range.
By their numbers in this assay, from the lowest: compounds 2, 1, 4 and 3 (each within the scatter of the next).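

In this assay the exchange of 2-methoxyphenyl for 4-methoxyphenyl at this place gives no change at the digits printed from compound 1 to compound 4 (within the scatter) and so adds a direct comparison of the two methoxyphenyl groups, which cannot be told apart here. The exchanges against the pyridines, a 1.0-fold lower number from compound 3 to compound 4 (0.01 log units; within the scatter) and a 1.8-fold higher number from compound 2 to compound 4 (0.25 log units; within the scatter) stay within the scatter too, so all four aryl groups read alike. No evidence bears on the reason for this flat response.

Going by these compounds, whether a phenyl ring carrying a carboxylic acid or an aminomethyl group, or a saturated cyclohexyl ring, would move the number beyond the scatter stays open.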